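Swapping fluoro for bromo where compound 3 sits at a limit

The source may report more compounds than this note shows. Statements on the series, on what has been measured and on what is new or still open speak of the compounds shown alone.

Compound 3 `Fc1ccccc1NC(=S)N/N=C/c1ccc2ccccc2n1` in a functional assay on SGC-7901 cells (Homo sapiens) for antiproliferative activity, read by sulforhodamine B assay, with a stated time of 72 h (on this read-out lower numbers stand for stronger inhibition and higher numbers for weaker inhibition), gives > 100000 nM, which is a limit of the assay rather than a number. Compound 1 `NC(=S)N/N=C/c1ccc2ccccc2n1` gives 32700 nM in this assay, and compound 2 `Fc1cccc(NC(=S)N/N=C/c2ccc3ccccc3n2)c1` gives 79900 nM. The measured steps show a 2.4-fold higher number from compound 1 to compound 2 (0.39 log units; beyond the scatter) and an at least 3.0-fold higher number from compound 1 to compound 3 (0.48 log units; beyond the scatter), while an at least 1.2-fold higher number from compound 2 to compound 3 (0.09 log units; that floor lies within the scatter). Compound 4 `S=C(N/N=C/c1ccc2ccccc2n1)Nc1ccccc1Br` differs from compound 3 by bromo in place of fluoro on an aromatic carbon. For the measured compounds named here, no measured step exchanges one halogen for another, so only the standing of compound 3 at the limit of > 100000 nM in this assay, at which 1 of the 3 values shown sits, bears on the change, and no step beyond the scatter in this assay is expected in either direction. Compound 4 is therefore estimated at 110000 nM, within 45000 nM to 250000 nM. The expected step is a step that the limit leaves unreadable from compound 3 to compound 4.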

Compound 4, half-maximal inhibitory concentration: > 100000 nM
Compound 4 ended at the assay's limit; the forecaster's own chance of this, stated with the estimate: 60%; the middle value is on the limit's open side.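

In this assay compound 4 joins compound 3 at a limit, so the exchange of fluoro for bromo cannot be read. The 2-bromophenyl group gives an at least 3.0-fold higher number from compound 1 to compound 4 (0.48 log units; beyond the scatter), as 2-fluorophenyl did, while replacing 3-fluorophenyl gives an at least 1.2-fold higher number from compound 2 to compound 4 (0.09 log units; that floor lies within the scatter). Both halogens at this position now end at the same limit: the limit of > 100000 nM in this assay, at which 2 of the 4 values shown sit.

On these data alone, whether an amine, a hydroxyl or a methoxy in place of the halogen would give a readable number stays open. So does the true size of the step from hydrogen to either 2-halophenyl group.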